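A few compounds are considered here, and "the series" means these few. Any claim that something is new, unique, unknown or untested is made for them only; others in the source may bear on it.

Measured so far in a functional assay on CHO cells for positive allosteric modulation of metabotropic glutamate receptor 2 (Homo sapiens), read by scintillation counting and GTPgammaS binding, with a stated time of 30 min; a higher number here means a larger maximal response, a lower number a smaller maximal response:

Compound 1, `Cc1ncccc1Oc1ccc(-c2ccn(CC3CC3)c(=O)c2C#N)cc1`: 155%
Compound 2, `Cc1ccc(Oc2ccc(-c3ccn(CC4CC4)c(=O)c3C#N)cc2)c(C)n1`: 183%
Compound 3, `CCCCn1ccc(-c2ccc(Oc3cccnc3C)c(Cl)c2)c(C#N)c1=O`: 236%

Compound 1 and compound 2 share a core and differ in one place, (methyl in place of hydrogen on an aromatic carbon). That single change gave a number 28 percentage points higher from compound 1 to compound 2 (beyond the scatter), a shift in maximal response that lies beyond the scatter but remains modest.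

Compound 3 stands on a different core; how its core differs from that of compound 1 is not broken down here. Its value in this assay is the largest of the three, and both compound 1 and compound 2 sit clearly lower.

Compound 4, `CCCCn1ccc(-c2ccc(Oc3ccc(C)nc3C)c(Cl)c2)c(C#N)c1=O`, is not yet measured. It relates to compound 3 by methyl in place of hydrogen on an aromatic carbon, the same change, in the same surroundings, as that from compound 1 to compound 2. Among the measured compounds shown here, the expectation for compound 4 therefore rests on compound 1 and compound 2, because a number 28 percentage points higher from compound 1 to compound 2 (beyond the scatter) is the only measured instance of this change. The step from compound 3 to compound 4 is expected to be a number 22 percentage points higher from compound 3 to compound 4 (beyond the scatter), of similar size to the earlier one; a single pair is a thin basis, so the range is kept wide. Compound 4 is estimated at 258%, between 222% and 296%.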

Compound 4, largest response reached (Emax), in percent of the reference or control that the assay uses: 231%
The estimate for compound 4 lay 27 percentage points above the measured number; the measured number falls inside the stated range.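

In this assay, going from 2-methylpyridin-3-yl to 2,6-dimethylpyridin-3-yl on the core of compound 3 gives a number 5 percentage points lower from compound 3 to compound 4 (within the scatter), so the step seen on the core of compound 1 does not recur here. Set side by side, the two steps disagree: the same change on two cores in this assay, a number 28 percentage points higher (beyond the scatter) from compound 1 to compound 2 and a number 5 percentage points lower (within the scatter) from compound 3 to compound 4, 33 percentage points apart, beyond the scatter of two such steps. This shows that the step measured on one core cannot be carried over to the other as a fixed increment in this series, but with a single pair on each core it does not show which feature of the cores separates the two results, nor how the change would behave on any further core.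

The compounds shown leave open whether another group in the same place, such as ethyl, methoxy or a fluorine atom, would also give different steps on the two cores. They also leave open how the methyl change would read on a core carrying a longer chain, such as pentyl, in place of the butyl chain.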